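Furan-2-yl Replacing 2-Chlorophenyl on a Fused Core

A few compounds are considered here, and "the series" means these few. Any claim that something is new, unique, unknown or untested is made for them only; others in the source may bear on it.

Compound 3 `CC(C)Cc1ccc(C(C)c2nnc3sc(-c4ccccc4Cl)nn23)cc1` gives 58% in a functional assay on the whole organism (strain Wistar albino) for inhibition, with Rattus norvegicus as the target, read by paw edema, with stated times of 30 min and 2.5 h, at a dose of 20 mg/kg by the oral route (on this read-out higher numbers stand for more inhibition at the one dose given (going by the name of the read-out) and lower numbers for less inhibition), the highest of the three measured numbers. Compound 1 `CCc1nn2c(C(C)c3ccc(CC(C)C)cc3)nnc2s1` gives 44% and compound 2 `CCCc1nn2c(C(C)c3ccc(CC(C)C)cc3)nnc2s1` gives 31%. The steps of a number 14 percentage points higher from compound 1 to compound 3 (beyond the scatter) and a number 27 percentage points higher from compound 2 to compound 3 (beyond the scatter) both put 2-chlorophenyl in place of a short chain and both raised the read-out, while the step of a number 13 percentage points lower from compound 1 to compound 2 (beyond the scatter) lengthened the chain and lowered it.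

Compound 4 `CC(C)Cc1ccc(C(C)c2nnc3sc(-c4ccco4)nn23)cc1` differs from compound 3 by one change: furan-2-yl in place of 2-chlorophenyl on an aromatic carbon. Among the compounds with values here, no measured step swaps one aromatic ring for another, so the expectation rests on compound 3 alone, with a mild lean downward. Compound 4 is estimated at 48%, between 33% and 62%. That corresponds to an expected step of a number 10 percentage points lower from compound 3 to compound 4 (within the scatter).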

Compound 4, a percentage reported as inhibition, in the whole organism at one dose (the size of the read-out at that dose, not a potency): 61%
Compound 4: the middle estimate sits 13 percentage points below what was measured; low and high end bracket the measured number.
By their numbers in this assay, from the lowest: compound 2; then compound 1; then compounds 3 and 4 (each within the scatter of the next).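

At this position, next to the ring sulfur, furan-2-yl serves as well as 2-chlorophenyl in this assay (a number 3 percentage points higher from compound 3 to compound 4 (within the scatter)), so neither the chlorine nor the six-membered ring is needed to hold the read-out here. The smaller aromatic ring also stands clear of both short chains (a number 30 percentage points higher from compound 2 to compound 4 (beyond the scatter); a number 17 percentage points higher from compound 1 to compound 4 (beyond the scatter)), as 2-chlorophenyl did. No measurement here explains why these two rings match. On these data alone, what a plain phenyl, a thiophene or an amine would give at this position stays open.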